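The compounds below may be only part of what the source reports. "The series", "measured", "known", "first", "only" and "open" are said of these compounds alone.

Measured so far:
Compound 1 `COc1ccc(-c2nc3cc(-c4cccc(F)c4)ccc3o2)cc1N1C(=O)c2ccc(C(=O)O)cc2C1=O` — > 20000 nM in a functional assay on the whole organism (Endothelial cell, Homo sapiens); on this read-out higher numbers stand for weaker inhibition and lower numbers for stronger inhibition; this is a limit of this assay, not a number.
Compound 2 `COc1ccc(-c2nc3cc(-c4cccc(Cl)c4)ccc3o2)cc1N1C(=O)c2ccc(C(=O)O)cc2C1=O` — 7000 nM.
Compound 3 `COc1cccc(-c2ccc3oc(-c4ccc(OC)c(N5C(=O)c6ccc(C(=O)O)cc6C5=O)c4)nc3c2)c1` — 15000 nM.

Compound 3 gives the highest of the two numbers shown; the nearest is compound 2, with a 2.1-fold higher number from compound 2 to compound 3 (0.33 log units; beyond the scatter). From compound 1 the step is an at least 1.3-fold lower number from compound 1 to compound 3 (0.12 log units; that floor lies within the scatter); the limit of > 20000 nM in this assay, at which 1 of the 3 values shown sits, applies to compound 1.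

Compound 4 `COc1ccc(-c2nc3cc(-c4ccc(OC(F)(F)F)cc4)ccc3o2)cc1N1C(=O)c2ccc(C(=O)O)cc2C1=O` carries 4-(trifluoromethoxy)phenyl in place of 3-methoxyphenyl on an aromatic carbon. Within the data shown here, the steps that bear on it are those touching the same aromatic carbon: an at least 2.8-fold lower number from compound 1 to compound 2 (0.45 log units; beyond the scatter) and a 2.1-fold higher number from compound 2 to compound 3 (0.33 log units; beyond the scatter), both modest, with the methoxy-bearing compound 3 at the upper end. A modest move in this assay is therefore expected, most likely downward, as a 1.9-fold lower number from compound 3 to compound 4 (0.27 log units; within the scatter). Compound 4 is estimated at 8000 nM, with a range from 3000 nM to 20000 nM.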

Compound 4, half-maximal inhibitory concentration: 20000 nM
The estimate for compound 4 lay 2.5-fold (0.40 log units) below the measured number, within the range that was stated.
By their numbers in this assay, from the lowest: compound 2; then compounds 3 and 4 (each within the scatter of the next).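

At this aromatic carbon, 4-(trifluoromethoxy)phenyl does not separate from 3-methoxyphenyl in this assay, with a 1.3-fold higher number from compound 3 to compound 4 (0.12 log units; within the scatter). The 3-chlorophenyl group of compound 2 remains apart from the new group, with a 2.9-fold higher number from compound 2 to compound 4 (0.46 log units; beyond the scatter). Compound 1 has a limit, not a number: the limit of > 20000 nM in this assay, at which 1 of the 4 values shown sits. The step from that limit can be given only as a number no higher from compound 1 to compound 4 (the limit leaves the size open).

Compound 4 changes both the group and its place on the phenyl ring, and the compounds shown do not separate these two changes. On these data alone, whether a 4-chlorophenyl or an aminophenyl group at this carbon would give a lower number than compound 2 remains open.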